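A few compounds are considered here, and "the series" means these few. Any claim that something is new, unique, unknown or untested is made for them only; others in the source may bear on it.

Working notes on the series in a functional assay on MKN-45 cells (Homo sapiens) for inhibition, with a stated time of 72 h; on this read-out lower numbers stand for stronger inhibition and higher numbers for weaker inhibition. Compound 1 `COc1ccc(S(=O)(=O)N2CCc3cccc(-c4ccc([N+](=O)[O-])cc4)c32)cc1` gives 34 nM, compound 2 `COc1ccc(S(=O)(=O)N2CCc3cccc(-c4ccc(F)c(F)c4)c32)cc1` gives 55.5 nM, and compound 3 `COc1ccc(S(=O)(=O)N2CCc3cccc(-c4ccncc4)c32)cc1` gives 69.5 nM. Compound 3 lies within the scatter of compound 2 and separates, modestly, only from compound 1: a 2.0-fold higher number from compound 1 to compound 3 (0.31 log units; beyond the scatter). Compound 4 `COc1ccc(S(=O)(=O)N2CCc3cccc(-c4cccc(F)c4)c32)cc1` carries 3-fluorophenyl in place of pyridin-4-yl on an aromatic carbon. Within the data shown here, the nearest precedent is the pair with 3,4-difluorophenyl and pyridin-4-yl, read in reverse: a 1.3-fold higher number from compound 2 to compound 3 (0.10 log units; within the scatter). The other step, a 1.6-fold higher number from compound 1 to compound 2 (0.21 log units; within the scatter), is also small. No step beyond the scatter is therefore expected, and the estimated step is a 1.2-fold lower number from compound 3 to compound 4 (0.08 log units; within the scatter). Compound 4 is expected at 58 nM, with an estimated range of 29 nM to 115 nM.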

Compound 4, half-maximal inhibitory concentration: 84.7 nM
Compound 4: the middle estimate sits 1.5-fold (0.16 log units) below what was measured; the range from low to high includes it.
By their numbers in this assay, from the lowest: compounds 1, 2, 3 and 4 (each within the scatter of the next, the first and the last beyond it).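

Exchanging pyridin-4-yl for 3-fluorophenyl, which removes the ring nitrogen, gives no separation at this position in this assay (a 1.2-fold higher number from compound 3 to compound 4 (0.09 log units; within the scatter)), and losing one fluoro from the 3,4-difluorophenyl group likewise gives none (a 1.5-fold higher number from compound 2 to compound 4 (0.18 log units; within the scatter)). Replacing 4-nitrophenyl with 3-fluorophenyl does separate, modestly (a 2.5-fold higher number from compound 1 to compound 4 (0.40 log units; beyond the scatter)). No measurement offers an explanation for these steps. As far as these compounds go, whether an amine or a carboxylic acid on this aryl ring would shift the number remains open. So does whether a saturated ring can replace the aryl group here.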